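The source may hold more compounds than are shown below. What is called first, only, known or untested is meant among the compounds shown, and "the series" means these compounds.

Going by the values given here, in an in vitro assay on BTI-TN-5B1-4 cells for inhibition of Amine oxidase [flavin-containing] B (Homo sapiens) (on this read-out lower numbers stand for stronger inhibition and higher numbers for weaker inhibition), three compounds have numbers so far. Compound 1 `COc1ccc(-c2cc(=O)c3ccc(OC)cc3o2)cc1` gives 49700 nM, compound 2 `COc1ccc(-c2cc(=S)c3ccc(OC)cc3o2)cc1` gives 3340 nM, and compound 3 `Cc1ccc(C2CC(=O)c3ccc(F)cc3O2)cc1` gives 160 nM. Compound 2 thus stands second highest of the three: its number lies well below that of compound 1 and well above that of compound 3, and both gaps are beyond the scatter. Among the compounds with values here, compound 1 and compound 2 differ in a single atom of the shared core, while compound 3 differs from both in several places at once, so no step resting on one change alone can be read off from the measured compounds.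

Compound 4 `COc1ccc(-c2cc(=S)c3ccccc3o2)cc1` is not yet measured. It arises from compound 2 by the change (hydrogen in place of methoxy on an aromatic carbon). Within the data shown here, no measured pair shows this change by itself, so its effect cannot be taken from the numbers so far. For compound 4 a small step in this assay is expected, toward a somewhat higher number, a 1.3-fold higher number from compound 2 to compound 4 (0.13 log units; within the scatter), and not clearly beyond the scatter. Compound 4 is accordingly estimated at 4500 nM, with a range from 1200 nM to 16000 nM.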

Compound 4, half-maximal inhibitory concentration: 480 nM
The estimate for compound 4 lay 9.4-fold (0.97 log units) above the measured number; the measured number lies below the stated range.
By their numbers in this assay, from the lowest: compound 3; then compound 4; then compound 2; then compound 1.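

In this assay, hydrogen in place of methoxy on this aromatic carbon, part of a fused or bridged system of two rings, gives a 7.0-fold lower number from compound 2 to compound 4 (0.84 log units; beyond the scatter), a change toward stronger inhibition. Going by these compounds alone, this is the first step here that rests on one change alone, and it shows that the methoxy at this place is not needed for inhibition and that inhibition is stronger without it. Nothing measured on these compounds explains why the number falls.

The compounds shown leave open whether a chlorine, a hydroxyl or an amine on this same carbon would give a number closer to that of compound 4 or to that of compound 2. They also leave open whether the same change would give a step of similar size on the core of compound 1, which carries a carbonyl where compound 2 carries sulfur.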